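The source may report more compounds than this note shows. Statements on the series, on what has been measured and on what is new or still open speak of the compounds shown alone.

Compound 1 `CCOC(=O)CCCCCOc1cccc(CN(C(=O)c2ccccc2)C(C)C)c1` and compound 2 `CCOC(=O)CCCCCOc1cccc(CN(C(=O)c2ccc(-c3ccc4[nH]ccc4c3)cc2)C(C)C)c1` share one amide core. In an ADME assay on BJ cells (Homo sapiens) for cytotoxicity, read by CellTiter-Glo and resazurin assay, with a stated time of 72 h (a higher number here means that more compound is needed for the effect, a lower number that less compound is needed), compound 1 returns only a limit, > 26000 nM. In this assay compound 2 likewise returns only a limit, > 26000 nM. The step that the two limits leave unreadable from compound 1 to compound 2 is therefore unreadable, both values sitting at the limit of > 26000 nM in this assay, at which 2 of the 2 values shown sit. Compound 3 `CCOC(=O)CCCCCOc1cccc(CN(C(=O)c2ccc(-c3cccc(OCC)c3)cc2)C(C)C)c1` carries 3-ethoxyphenyl in place of 1H-indol-5-yl on an aromatic carbon. Among the measured compounds shown here, no measured step bears on this exchange, since the one recorded step is itself unreadable. The expected step that the limit leaves unreadable from compound 2 to compound 3 is estimated as none beyond the scatter. Compound 3 is expected to give about 30000 nM, in the range 10000 nM to 90000 nM, most probably again as a limit.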

Compound 3, half-maximal effective concentration: > 22300 nM
Compound 3 gave a limit, no number; the forecaster's own chance of this, stated with the estimate: 80%; the middle value does not contradict the limit.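

Among the compounds shown here, compound 1, compound 2 and compound 3 all stand only as limits in this assay, and no step among them can be read. Open remains whether 1H-indol-5-yl and 3-ethoxyphenyl differ at all in this read-out.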